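The source may report more compounds than this note shows. Statements on the series, on what has been measured and on what is new or still open speak of the compounds shown alone.

Compound 2 `NC(=O)c1cn(C2O[C@H](CO)[C@@H](O)[C@H]2O)nc1C(N)=O` was tested in a functional assay on HL-60 cells (Homo sapiens) for inhibition (on this read-out higher numbers stand for weaker inhibition and lower numbers for stronger inhibition), where compound 2 gave 58 uM. That is the higher of the two numbers recorded, though compound 1 `NC(=O)c1nn([C@@H]2O[C@H](CO)[C@@H](O)[C@H]2O)nc1C(N)=O`, which in this assay gave 32 uM, sits within the scatter of it, so the two cannot be told apart. Compound 3 `NC(=O)c1nn(C2O[C@H](CO)[C@@H](O)[C@H]2O)c(N)c1C(N)=O` differs from compound 2 by amino in place of hydrogen on an aromatic carbon, an amino in place of hydrogen on an aromatic carbon. For the measured compounds named here, no measured pair isolates this change, so no step beyond the scatter is expected from compound 2 to compound 3. Compound 3 is estimated at 50 uM in this assay, in a range from 18 uM to 140 uM, the expected step being a 1.2-fold lower number from compound 2 to compound 3 (0.06 log units; within the scatter).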

Compound 3, concentration for 50% inhibition: 39 uM
Beside the measured number, compound 3's estimate is 1.3-fold (0.11 log units) above it; low and high end bracket the measured number.
By their numbers in this assay, from the lowest: compounds 1, 3 and 2 (each within the scatter of the next).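

In this assay, amino in place of hydrogen on this aromatic carbon gives a 1.5-fold lower number from compound 2 to compound 3 (0.17 log units; within the scatter) and so does not separate compound 3 from compound 2. For the compounds shown here, this is the first pair differing in one place, and it shows that this position accepts the amino group with no step that can be told from the scatter. Nothing measured here accounts for this result. As far as these compounds go, whether a methyl, a hydroxyl or a dimethylamino group on the same carbon would move the number beyond the scatter stays open.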